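Swapping Formyl for Bromo in a Cytotoxicity Series

This account rests on a few compounds, and the source may have more. Where it says the series, first, only, none or still open, it means among the compounds named here.

Of the compounds shown here, two sharing one core have been measured in an ADME assay on Vero cells (Chlorocebus sabaeus) for cytotoxicity, read by MTT assay, with a stated time of 72 h; a lower number here means that less compound is tolerated, a higher number that more compound is tolerated. There, compound 1 (`CC/C(=C\c1ccc(Cl)cc1)C(=O)/C=C/c1ccccc1Br`) gives 24400 nM, and compound 2 (`CC/C(=C\c1ccc(Cl)cc1)C(=O)/C=C/c1ccc(C=O)cc1`) gives 46900 nM. These two numbers lie within the usual scatter of each other, so compound 2 does not stand apart from compound 1 on the data so far.

The next compound, compound 3 (`CC/C(=C\c1ccc(Cl)cc1)C(=O)/C=C/c1ccc(Br)cc1`), has bromo in place of formyl on an aromatic carbon of compound 2, para to a large group: bromo in place of formyl on an aromatic carbon. Within the data shown here, no measured pair of compounds differs in only one place, so this change has no direct precedent in the data. Among the measured compounds shown here, the only guide is compound 1, the one measured compound that carries a bromo group, with its 24400 nM in this assay.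

On that slender basis, a small move towards a lower number is expected, about the size of the scatter, and the estimated step is a 1.8-fold lower number from compound 2 to compound 3 (0.26 log units; within the scatter). For compound 3 the expected value is 26000 nM, with an estimated range of 11000 nM to 60000 nM.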

Compound 3, half-maximal cytotoxic concentration: 29400 nM
For compound 3 the middle estimate is 1.1-fold (0.05 log units) below the measured one; the measured number falls inside the stated range.
By their numbers in this assay, from the lowest: compounds 1, 3 and 2 (each within the scatter of the next).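

In this assay, among these compounds, the bromo group on this aromatic carbon, para to a large group, gives a first direct comparison with formyl: the exchange comes to a 1.6-fold lower number from compound 2 to compound 3 (0.20 log units; within the scatter), so the two groups cannot be told apart at this place, even though bromo has one heavy atom, formyl has two, and only formyl counts a hydrogen-bond acceptor. Among the compounds shown here, the pair sharing a bromo group adds a comparison the earlier compounds could not give, since 4-bromophenyl in place of 2-bromophenyl comes to a 1.2-fold higher number from compound 1 to compound 3 (0.08 log units; within the scatter), and this change also stays inside the usual variation between repeated measurements. Nothing at hand bears on why these three compounds remain so close in this assay.

Going by these compounds, whether an amine or a carboxylic acid at this place on the aromatic ring would give a step beyond the scatter remains open, as the two groups compared here span only a narrow range of what could sit there. On these data alone, all three compounds also keep the rest of the shared core, so what a change elsewhere in it would do to tolerated concentration is unknown.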